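Swapping the benzyl group on compound 2

The source may hold more compounds than are shown below. What is called first, only, known or untested is meant among the compounds shown, and "the series" means these compounds.

Measured in a functional assay on MCF7 cells (Homo sapiens) for inhibition, read by CCK-8 assay, with a stated time of 48 h; a lower number here means a stronger inhibitor of growth, a higher number a weaker inhibitor of growth:
compound 1 `Cc1ccccc1Nc1nc(Nc2ccc(N3CCN(C)CC3)cn2)ncc1Cl`: 5210 nM
compound 2 `CN1CCN(c2ccc(Nc3ncc(Cl)c(NCc4ccc(C(F)(F)F)cc4)n3)nc2)CC1`: 28400 nM

Of the two measured compounds, compound 2 stands highest at 28400 nM, making it the weaker inhibitor of growth. Compound 3 `COc1cccc(CNc2nc(Nc3ccc(N4CCN(C)CC4)cn3)ncc2Cl)c1` has 3-methoxyphenyl in place of 4-(trifluoromethyl)phenyl on a saturated chain carbon bound to a nitrogen on an aromatic ring. Within the data shown here, the only measured step, a 5.5-fold higher number from compound 1 to compound 2 (0.74 log units; beyond the scatter), is a modest one that involved a different exchange, so it is a loose guide to size. No measurement tests this swap directly. The expected step in this assay is modest and downward, a 2.0-fold lower number from compound 2 to compound 3 (0.31 log units; beyond the scatter). Compound 3 is estimated at 14000 nM, with an expected range of 5000 nM to 35000 nM.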

Compound 3, concentration for 50% growth inhibition: 19500 nM
For compound 3 the middle estimate is 1.4-fold (0.14 log units) below the measured one, within the range that was stated.
By their numbers in this assay, from the lowest: compound 1; then compounds 3 and 2 (each within the scatter of the next).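

In this assay, exchanging 4-(trifluoromethyl)phenyl for 3-methoxyphenyl on the saturated chain carbon gives a 1.5-fold lower number from compound 2 to compound 3 (0.16 log units; within the scatter), so this change leaves compound 2 and compound 3 indistinguishable, despite the different group and the added hydrogen-bond acceptor. The 3-methoxybenzyl group still gives a 3.7-fold higher number from compound 1 to compound 3 (0.57 log units; beyond the scatter), so both benzyl compounds remain apart from the 2-methylphenyl of compound 1. No experimental evidence explains either result.

As far as these compounds go, whether an amine or a carboxylic acid on this ring would shift the number remains open. So does the effect of a longer chain between the ring and the nitrogen.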